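This account rests on a few compounds, and the source may have more. Where it says the series, first, only, none or still open, it means among the compounds named here.

Compound 2 `CCCCc1ccc2[nH]c(-c3ccc(OC)cc3)c(C3=C(Br)C(=O)NC3=O)c2c1` is measured in a physicochemical assay for lipophilicity (a lower number here means a more polar compound, a higher number a more lipophilic compound), where it gives 3.83. Two close relatives differ from it only in the length of the saturated chain on the shared core. Compound 1 `CCCc1ccc2[nH]c(-c3ccc(OC)cc3)c(C3=C(Br)C(=O)NC3=O)c2c1` gives 3.45, and the step of a number 0.38 log units higher from compound 1 to compound 2 (beyond the scatter) is a modest rise. Compound 3 `CCCCCc1ccc2[nH]c(-c3ccc(OC)cc3)c(C3=C(Br)C(=O)NC3=O)c2c1` gives 4.1; the step of a number 0.27 log units higher from compound 2 to compound 3 (within the scatter) stays within the scatter, so the two cannot be told apart on this number. The longer step of a number 0.65 log units higher from compound 1 to compound 3 (beyond the scatter) shows the same direction once more.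

Compound 4 `CCCCc1ccc2[nH]c(-c3cccc(OC)c3)c(C3=C(Br)C(=O)NC3=O)c2c1` keeps the chain of compound 2 and changes only the position of one group: 3-methoxyphenyl in place of 4-methoxyphenyl on an aromatic carbon. Within the data shown here, none of the measured steps touches this position; all three vary the chain and leave the methoxyphenyl untouched, so no measured step bears directly on this change. The same atoms are joined differently, nothing is added or removed, and so the expected step of no change at the digits printed from compound 2 to compound 4 (within the scatter) is none beyond the scatter. Compound 4 is therefore estimated at 3.83, with a range from 3.5 to 4.15.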

Compound 4, partition coefficient: 3.81
For compound 4 the middle estimate is 0.02 log units above the measured one; the range from low to high includes it.
By their numbers in this assay, from the lowest: compound 1; then compounds 4, 2 and 3 (each within the scatter of the next).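

Until this pair, every measured step varied the saturated chain, so nothing had tested the methoxyphenyl group on the shared core. In this assay, 3-methoxyphenyl in place of 4-methoxyphenyl gives a number 0.02 log units lower from compound 2 to compound 4 (within the scatter), so compound 2 and compound 4 cannot be told apart on this number. This holds for one pair with one chain length, and nothing available offers an explanation for the result.

Going by these compounds, whether the same swap would also leave the number within the scatter on the shorter chain of compound 1 or the longer chain of compound 3 remains open. Also open, on these data alone, is what a different group at this place would do, such as a phenyl ring carrying an amine or a carboxylic acid in place of the methoxy group.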